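Half-life in rat after swapping an aryl ring for cyclohexyl

This account rests on a few compounds, and the source may have more. Where it says the series, first, only, none or still open, it means among the compounds named here.

Measured compounds:
compound 1 `CC(C)c1ccc2c(Nc3cc(C(=O)N[C@@](C)(CO)c4ccccc4)ccc3Sc3ccc(N)cc3)ncnc2n1` — 1.1 h
compound 2 `CC(C)c1ccc2c(Nc3cc(C(=O)N[C@@H](C)c4ccc(Br)cc4)ccc3Sc3ccc(N)cc3)ncnc2n1` — 1.9 h

For the measured compounds named here, in an ADME assay on the whole organism (strain Sprague-Dawley) for metabolic stability, with Rattus norvegicus as the target, at a dose of 5 mg/kg by the intravenous route (on this read-out higher numbers stand for a longer-lived compound and lower numbers for a shorter-lived compound), compound 2 gives 1.9 h, the higher of the two numbers; its only neighbour is compound 1 with 1.1 h, and the step of a 1.7-fold higher number from compound 1 to compound 2 (0.24 log units; within the scatter) stays within the scatter. Compound 3 `CC(C)c1ccc2c(Nc3cc(C(=O)N[C@@H](C)C4CCCCC4)ccc3Sc3ccc(N)cc3)ncnc2n1` differs from compound 2 by cyclohexyl in place of 4-bromophenyl on a saturated chain carbon bound to an amide-type nitrogen and a saturated chain carbon. Going by the values given here, no measured step replaces an aromatic ring with a saturated one, so the one step at hand, a 1.7-fold higher number from compound 1 to compound 2 (0.24 log units; within the scatter), bears on it only loosely: it shows that a change on this side chain left the half-life within the scatter. Compound 3 is therefore expected to sit close to compound 2, with a step of a 1.1-fold lower number from compound 2 to compound 3 (0.05 log units; within the scatter) that need not exceed the scatter. Compound 3 is estimated at 1.7 h, within a range from 0.8 h to 3.5 h.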

Compound 3, half-life: 0.5 h
For compound 3 the middle estimate is 3.4-fold (0.53 log units) above the measured one; measured number outside the range, below it.
By their numbers in this assay, from the lowest: compound 3; then compounds 1 and 2 (each within the scatter of the next).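

In this assay, the side chain on the amide-type nitrogen now shows a change beyond the scatter: cyclohexyl in place of 4-bromophenyl gives a 3.8-fold lower number from compound 2 to compound 3 (0.58 log units; beyond the scatter) on the same saturated chain carbon. 1-Cyclohexylethyl in place of 1-(hydroxymethyl)-1-phenylethyl points the same way, with a 2.2-fold lower number from compound 1 to compound 3 (0.34 log units; beyond the scatter) at this position. Among these three compounds, therefore, the half-life is shortest with the saturated ring, and the data shown offer no explanation for this.

Compound 2 and compound 3 differ in both the ring and the bromine, so the compounds shown leave open how much each contributes. A plain phenyl on the same chain would separate the two, and a hydroxymethyl on the cyclohexyl ring would show whether the saturated ring tolerates that group.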